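The source may report more compounds than this note shows. Statements on the series, on what has been measured and on what is new or still open speak of the compounds shown alone.

Working notes on the series in a functional assay, read by fluorescence and spectrophotometry, with a stated time of 1 h; a lower number here means that less compound is needed, a higher number that more compound is needed for the effect. Compound 1 (`O=S(=O)(/C=C/c1ccc(O)c(O)c1)CCCCCCCCO`) gives 6700 nM, compound 2 (`CCCCCCCCCS(=O)(=O)/C=C/c1ccc(O)c(O)c1`) gives 7700 nM, and compound 3 (`CCCCCCCCS(=O)(=O)/C=C/c1ccc(O)c(O)c1`) gives 6400 nM. Compound 3 therefore stands within the scatter of both other compounds, and the three values cannot be ranked.

The next compound is compound 4 (`C=CCCCCCS(=O)(=O)/C=C/c1ccc(O)c(O)c1`), and the difference is vinyl in place of propyl on a saturated chain carbon, five bonds along the chain from a sulfonyl sulfur.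

The measured steps that bear on this all lie at the chain end, eight bonds along the chain from a sulfonyl sulfur: a 1.0-fold lower number from compound 1 to compound 3 (0.02 log units; within the scatter), a 1.2-fold lower number from compound 2 to compound 3 (0.08 log units; within the scatter) and a 1.1-fold higher number from compound 1 to compound 2 (0.06 log units; within the scatter). All three are within the scatter. For the measured compounds named here, no measured compound carries vinyl at this place, so the series offers no direct precedent. Given how small those steps are, no change beyond the scatter is expected in this assay, and no direction is favoured.

The estimated step is a 1.0-fold higher number from compound 3 to compound 4 (0.01 log units; within the scatter). Compound 4 is expected at 6500 nM, with an estimated range from 3500 nM to 12000 nM.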

Compound 4, half-maximal effective concentration: 7100 nM
Estimate against measurement, compound 4: 1.1-fold (0.04 log units) below; the range from low to high includes it.
By their numbers in this assay, from the lowest: compounds 3, 1, 4 and 2 (each within the scatter of the next).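

The earlier steps shown here all lie eight bonds along the chain from a sulfonyl sulfur, whereas this change sits five bonds along it and brings in a double bond outside aromatic rings. In this assay the three comparisons read a 1.1-fold higher number from compound 3 to compound 4 (0.05 log units; within the scatter) and a 1.1-fold lower number from compound 2 to compound 4 (0.04 log units; within the scatter) and a 1.1-fold higher number from compound 1 to compound 4 (0.03 log units; within the scatter) with the chain end as vinyl, so this shorter, unsaturated chain end stays within the scatter of all three earlier compounds. No supporting data are available to account for these results.

The change from propyl to vinyl alters chain length and saturation together, so a saturated chain of the same length as in compound 4 would be needed to separate the two. As far as these compounds go, whether an amine or a carboxylic acid at the chain end would move the number beyond the scatter remains open.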